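Piperidine amide series: microsomal half-life notes

The source may hold more compounds than are shown below. What is called first, only, known or untested is meant among the compounds shown, and "the series" means these compounds.

Measured compounds:
compound 1 `CC[C@@H]1C[C@H](CC)CN(CCCNC(=O)C2CCN(Cc3nc(-c4ccccc4C)oc3C)CC2)C1` — 0.0917 h
compound 2 `Cc1oc(-c2c(Cl)cccc2Br)nc1CN1CCC(C(=O)NCCCN2C[C@H](C)C[C@H](C)C2)CC1` — 0.0233 h

In an ADME assay on microsomes from liver (Rattus norvegicus) for metabolic stability, read by LC-MS, using NADPH, at 37 degrees C (on this read-out lower numbers stand for a shorter-lived compound and higher numbers for a longer-lived compound), compound 1 holds the higher of the two numbers, with compound 2 well below it and the gap beyond the scatter. Compound 3 `Cc1ccccc1-c1nc(CN2CCC(C(=O)NCCCCN3C[C@H](C)C[C@H](C)C3)CC2)c(C)o1` is not yet measured. It differs from compound 1 as follows: (3,5-dimethylpiperidin-1-yl)methyl in place of 3,5-diethylpiperidin-1-yl on a saturated chain carbon, three bonds along the chain from an amide-type nitrogen. Both measured values are short, and nothing measured separates this change from scatter. The step from compound 1 to compound 3 is expected to be small, a 1.2-fold higher number from compound 1 to compound 3 (0.08 log units; within the scatter), in no clear direction. Compound 3 is estimated at 0.11 h, with a range from 0.05 h to 0.25 h.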

Compound 3, half-life: 0.2 h
The estimate for compound 3 lay 1.8-fold (0.26 log units) below the measured number; measured number inside the range.
By their numbers in this assay, from the lowest: compound 2; then compound 1; then compound 3.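

In this assay, the first step read at this saturated chain carbon, three bonds along the chain from an amide-type nitrogen, is a 2.2-fold higher number from compound 1 to compound 3 (0.34 log units; beyond the scatter) and lies beyond the scatter, so this position responds to the change even though the step is modest. Nothing measured here bears on what lies behind the step. The change alters both the chain and the groups on the piperidine, and the compounds shown do not separate these two parts. Going by these compounds, a 3-(3,5-diethylpiperidin-1-yl)propyl group would bear on that split, and a morpholin-4-yl group at this place also remains open.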